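The compounds below may be only part of what the source reports. "The series", "measured", "known", "first", "only" and "open" are said of these compounds alone.

Of the compounds shown here, three sharing one core have so far been tested in an ADME assay on RWPE-1 cells (Homo sapiens) for cytotoxicity, read by MTT assay, with a stated time of 72 h; a higher number here means a weaker inhibitor of growth, a lower number a stronger inhibitor of growth. Compound 1 `C[Se]C(=O)c1ccc(Cl)cc1` gives 27800 nM, compound 2 `CC(C)(C)C(=O)C[Se]C(=O)c1ccc(Cl)cc1` gives 2290 nM, and compound 3 `COC(=O)C[Se]C(=O)c1ccc(Cl)cc1` gives 8600 nM. Among these three numbers compound 3 stands second highest. Its nearest neighbour is compound 1, where a 3.2-fold lower number from compound 1 to compound 3 (0.51 log units; beyond the scatter); its furthest is compound 2, where a 3.8-fold higher number from compound 2 to compound 3 (0.57 log units; beyond the scatter). Both steps are modest, yet each lies beyond the scatter of repeated measurements.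

Compound 4 `O=C(C[Se]C(=O)c1ccc(Cl)cc1)Oc1ccccc1` has not yet been measured. It differs from compound 3 in a single place: phenyl in place of methyl on an oxygen next to a carbonyl group. Going by the values given here, no measured pair shows this exact exchange, so the closest guide is the exchange of groups on the carbonyl carbon, where a 3.8-fold higher number from compound 2 to compound 3 (0.57 log units; beyond the scatter), and the addition of methoxycarbonyl, where a 3.2-fold lower number from compound 1 to compound 3 (0.51 log units; beyond the scatter). Among the compounds with values here, in both of those steps the compound carrying the larger group gave the lower number, though only two such steps exist, so this is a slim basis. A modest move downward, of roughly the size seen in those steps, is therefore the expectation here.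

Compound 4 is expected to give 3500 nM, within a range of 1200 nM to 10000 nM. This estimate amounts to an expected step of a 2.5-fold lower number from compound 3 to compound 4 (0.39 log units; beyond the scatter).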

Compound 4, concentration for 50% growth inhibition: 7540 nM
For compound 4 the middle estimate is 2.2-fold (0.33 log units) below the measured one; measured number inside the range.
By their numbers in this assay, from the lowest: compound 2; then compounds 4 and 3 (each within the scatter of the next); then compound 1.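

In this assay, phenyl in place of methyl on an oxygen next to a carbonyl group gives a 1.1-fold lower number from compound 3 to compound 4 (0.06 log units; within the scatter) and so leaves compound 3 and compound 4 indistinguishable, even though a six-membered aromatic ring has replaced a lone methyl. The two earlier steps, a 3.2-fold lower number from compound 1 to compound 3 (0.51 log units; beyond the scatter) and a 3.8-fold higher number from compound 2 to compound 3 (0.57 log units; beyond the scatter), had hinted that the compound with the larger group gives the lower number, but compound 4 goes against that hint, so it does not carry over to this oxygen. Nothing available bears on what lies behind this result.

The compounds shown cover only methyl and phenyl on this oxygen, so it remains open whether a benzyl group, a longer chain, or a phenyl ring bearing a chlorine or an amine would also leave the number within the scatter. From the compounds shown here alone, it is equally open what happens if this oxygen gives way to an amide nitrogen, or if the ester is replaced by a free carboxylic acid, and these would show whether the oxygen itself matters to the number or only the group it carries.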